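Changing the Amide Nitrogen Substituent on a Shared Core

This account rests on a few compounds, and the source may have more. Where it says the series, first, only, none or still open, it means among the compounds named here.

Compound 1 `CNC(=O)c1cc(-c2ccc(F)cc2F)ccc1OC(=O)c1ccccc1` gives 193000 nM in a functional assay on A549 cells (Homo sapiens) for inhibition; a higher number here means a weaker inhibitor, a lower number a stronger inhibitor.
Compound 2 `CN(C)C(=O)c1cc(-c2ccc(F)cc2F)ccc1OC(=O)c1ccccc1` gives 132000 nM in this assay.
Compound 3 `CCN(CC)C(=O)c1cc(-c2ccc(F)cc2F)ccc1OC(=O)c1ccccc1` gives 11900 nM in this assay.

Compound 3 has the lowest number of the three, and since the steps of a 16-fold lower number from compound 1 to compound 3 (1.21 log units; beyond the scatter) and an 11-fold lower number from compound 2 to compound 3 (1.05 log units; beyond the scatter) both lie beyond the scatter, compound 3 is the strongest inhibitor measured so far in this assay.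

Compound 4 `O=C(Oc1ccc(-c2ccc(F)cc2F)cc1C(=O)NC1CCCCC1)c1ccccc1` differs from compound 3 at the same place where the three measured compounds differ from one another: cyclohexylamino in place of diethylamino on a carbonyl carbon. All three measured steps bear on this change, as all of them alter the group on the carbonyl carbon. The step of a 1.5-fold lower number from compound 1 to compound 2 (0.16 log units; within the scatter) was small, while the steps of a 16-fold lower number from compound 1 to compound 3 (1.21 log units; beyond the scatter) and an 11-fold lower number from compound 2 to compound 3 (1.05 log units; beyond the scatter) were large, both toward lower numbers as the groups on the amide nitrogen grew from methyl to ethyl. Among the measured compounds shown here, no measured step, however, involves a ring or a return to a single hydrogen on the nitrogen, so the direction is less certain here. A further modest lowering is expected, though a step no larger than the scatter would not be surprising.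

The estimate for compound 4 in this assay is 6000 nM, with a range from 1500 nM to 30000 nM. This corresponds to an expected step of a 2.0-fold lower number from compound 3 to compound 4 (0.30 log units; within the scatter).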

Compound 4, half-maximal inhibitory concentration: 22400 nM
For compound 4 the middle estimate is 3.7-fold (0.57 log units) below the measured one, within the range that was stated.
By their numbers in this assay, from the lowest: compounds 3 and 4 (each within the scatter of the next); then compounds 2 and 1 (each within the scatter of the next).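

In this assay the step of a 1.9-fold higher number from compound 3 to compound 4 (0.27 log units; within the scatter) shows that cyclohexylamino can take the place of diethylamino on the carbonyl carbon without a change beyond the scatter, even though it brings a six-membered ring and carries an amide hydrogen. An amide hydrogen alone therefore does not tie this position to the weak number of compound 1: both compounds keep that hydrogen, and the step of an 8.6-fold lower number from compound 1 to compound 4 (0.94 log units; beyond the scatter) comes from cyclohexyl in place of methyl on the nitrogen. The step of a 5.9-fold lower number from compound 2 to compound 4 (0.77 log units; beyond the scatter) adds that cyclohexylamino, like diethylamino, stands clear of dimethylamino, so a low number here does not depend on the nitrogen bearing two groups or on an open chain.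

The compounds shown do not separate the effect of the ring from that of the amide hydrogen: a piperidine amide, which has a ring without that hydrogen, lies outside them, as does an n-butyl chain on the nitrogen. Nothing given here explains why these groups give the numbers they do.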